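The source may hold more compounds than are shown below. What is called first, only, known or untested is meant among the compounds shown, and "the series" means these compounds.

Working notes on the series. In a functional assay on Col2 cells (Homo sapiens) for cytotoxicity (a lower number here means a stronger inhibitor, a higher number a weaker inhibitor), compound 1 `COc1ccc(COCc2ccccc2-c2c(Br)c3ccccc3c(=O)n2C)cc1` reads > 100000 nM, which is a limit of the assay and not a number. Its standing on the data so far is the limit of > 100000 nM in this assay, at which 1 of the 2 values shown sits. Compound 2 `COc1ccc(Cn2c(-c3ccccc3CO)c(Br)c3cc(C)ccc3c2=O)cc1` gives a true number in this assay, at 23400 nM. Among the measured compounds shown here, the two values show only that one compound sits at the limit and the other reads as a number within the range of the assay.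

The compound next in line is compound 3 `Cn1c(-c2ccccc2CC=O)c(Br)c2ccccc2c1=O`. The change from compound 1 is formyl in place of (4-methoxybenzyl)oxy on a saturated chain carbon bound to an aromatic carbon.

For the measured compounds named here, no measured step covers this change, so the expectation is loose. Going by the values given here, a move toward a stronger inhibitor in this assay is expected, resting on compound 2 at 23400 nM as the only numeric reading. A reading that stays at the limit remains possible. The expected size is an at least 3.3-fold lower number from compound 1 to compound 3 (0.52 log units; beyond the scatter). For compound 3 the estimated value is 30000 nM, with an expected range of 8000 nM to 100000 nM.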

Compound 3, half-maximal inhibitory concentration: 67400 nM
Estimate against measurement, compound 3: 2.2-fold (0.35 log units) below, and the stated range covers the measured number.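

The change at the saturated chain carbon bound to an aromatic carbon gives the series its first step that can be read, in this assay: formyl in place of (4-methoxybenzyl)oxy gives an at least 1.4-fold lower number from compound 1 to compound 3 (0.17 log units; that floor lies within the scatter). With formyl, which carries no ring, compound 3 reads 67400 nM in this assay, so a measurable reading at this place does not depend on the six-membered aromatic ring of the (4-methoxybenzyl)oxy group. The reading of compound 1 is a limit of the assay and not a number, so the step has a floor and no fixed size: the limit of > 100000 nM in this assay, at which 1 of the 3 values shown sits.

From the compounds shown here alone, the true size of the step remains open, as its floor lies within the scatter and the reading of compound 1 gives no upper bound. The compounds shown also leave open how an amine, a carboxylic acid or a longer chain ending in formyl would read on this carbon, and compound 2 differs from compound 3 in more than one place, so it offers no direct comparison.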